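Swapping Fluoro for Trifluoromethyl on a Sulfonyl Benzimidazole Pair

The source may hold more compounds than are shown below. What is called first, only, known or untested is meant among the compounds shown, and "the series" means these compounds.

Measured so far:
- compound 1, `Cc1ccc(C)c(S(=O)(=O)n2c(-c3cn(-c4ccccc4)nc3-c3ccc(F)cc3)nc3ccccc32)c1`: 410 nM
- compound 2, `O=S(=O)(c1ccc(C(F)(F)F)cc1)n1c(-c2cn(-c3ccccc3)nc2-c2ccc(F)cc2)nc2ccccc21`: 1680 nM

Both compounds were tested in a functional assay on HepG2 cells (Homo sapiens) for antiproliferative activity, read by MTT assay, with a stated time of 24 h; a higher number here means a weaker inhibitor, a lower number a stronger inhibitor. Among the compounds with values here, compound 2 has the higher of the two numbers, and the only measured step, a 4.1-fold higher number from compound 1 to compound 2 (0.61 log units; beyond the scatter), lies beyond the scatter; that step changes the group on the sulfonyl sulfur, not the part that is altered next.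

Compound 3, `O=S(=O)(c1ccc(C(F)(F)F)cc1)n1c(-c2cn(-c3ccccc3)nc2-c2ccc(C(F)(F)F)cc2)nc2ccccc21`, has not yet been measured. It differs from compound 2 in one place: trifluoromethyl in place of fluoro on an aromatic carbon. Within the data shown here, this is a change on the aromatic ring attached to the shared core, a site where no measured step exists, so the single step from compound 1 to compound 2 speaks to it only indirectly, as a sign that groups of this kind can shift the number by a modest amount. Among the measured compounds shown here, with no direct precedent, no step beyond the scatter is predicted in either direction, and the estimate stays close to compound 2.

Compound 3 is therefore expected to give 2000 nM, with a range from 800 nM to 5000 nM. The estimated step is a 1.2-fold higher number from compound 2 to compound 3 (0.08 log units; within the scatter).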

Compound 3, half-maximal inhibitory concentration: 1120 nM
Beside the measured number, compound 3's estimate is 1.8-fold (0.25 log units) above it, within the range that was stated.
By their numbers in this assay, from the lowest: compound 1; then compounds 3 and 2 (each within the scatter of the next).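

Going from 4-fluorophenyl to 4-(trifluoromethyl)phenyl is the first change shown at this position, and in this assay it gives a 1.5-fold lower number from compound 2 to compound 3 (0.18 log units; within the scatter). A trifluoromethyl group, with four heavy atoms, can therefore replace a single fluoro on this aromatic carbon without a shift that stands clear of ordinary measurement scatter, at least when the sulfonyl sulfur carries 4-(trifluoromethyl)phenyl. Among the compounds shown, the only step beyond the scatter is still the change on the sulfonyl sulfur, a 4.1-fold higher number from compound 1 to compound 2 (0.61 log units; beyond the scatter), and nothing available explains why the new swap has so small an effect.

Two comparisons at this position cannot be judged from these compounds: whether an amine, a carboxylic acid or a longer chain in the same place would move the number beyond the scatter, and whether a hydrogen there would differ from fluoro and trifluoromethyl. As far as these compounds go, it also remains open whether the same swap would have an equally small effect with the 2,5-dimethylphenyl group of compound 1 on the sulfonyl sulfur.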